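Removing the chloro group from compound 1

The source may hold more compounds than are shown below. What is called first, only, known or untested is meant among the compounds shown, and "the series" means these compounds.

Compound 1 `CCn1cc(C(=O)O)c(=O)c2cc(F)c(N3CCN(C(=N)NS(=O)(=O)c4cccc(Cl)c4)CC3)cc21`: 32 nM
Compound 2 `N=C(NS(=O)(=O)c1cccc(Cl)c1)N1CCN(c2cc3c(cc2F)c(=O)c(C(=O)O)cn3C2CC2)CC1`: 32 nM

In a functional assay on HeLa cells (Homo sapiens) for antiproliferative activity, read by MTT assay, with a stated time of 72 h (a lower number here means a stronger inhibitor, a higher number a weaker inhibitor), compound 1 stands level with compound 2. Compound 3 `CCn1cc(C(=O)O)c(=O)c2cc(F)c(N3CCN(C(=N)NS(=O)(=O)c4ccccc4)CC3)cc21` carries hydrogen in place of chloro on an aromatic carbon, meta to a large group: hydrogen in place of chloro on an aromatic carbon. Among the measured compounds shown here, the only measured step, no change at the digits printed from compound 1 to compound 2 (within the scatter), is cyclopropyl in place of ethyl on an aromatic nitrogen. For the measured compounds named here, that change lies elsewhere, so it says little here, and no measured pair tests the chloro group. Only a small weakening in this assay is expected, perhaps none beyond the scatter. The expected step is a 1.4-fold higher number from compound 1 to compound 3 (0.15 log units; within the scatter). For compound 3 the estimated value is 45 nM, with a wide range of 12 nM to 170 nM.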

Compound 3, half-maximal inhibitory concentration: 32 nM
Beside the measured number, compound 3's estimate is 1.4-fold (0.15 log units) above it; the range from low to high includes it.
By their numbers in this assay, from the lowest: compounds 1, 2 and 3 (each within the scatter of the next).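

In this assay, among the compounds shown here, going from 3-chlorophenyl to phenyl gives no change at the digits printed from compound 1 to compound 3 (within the scatter) and so tests this position directly for the first time. The chloro group is therefore not required for the activity of compound 1, and the plain phenyl serves equally well on this core. Nothing measured here explains this result.

On these data alone, whether a larger or different group at this place, such as methoxy or an amine, would keep the number level stays open. As far as these compounds go, whether the chloro group can also be removed from compound 2 without a change stays open too.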